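This account rests on a few compounds, and the source may have more. Where it says the series, first, only, none or still open, it means among the compounds named here.

Measured so far in a functional assay on SK-MEL-147 cells (Homo sapiens) for cytotoxicity, read by MTT assay, with a stated time of 24 h; a lower number here means that less compound is needed, a higher number that more compound is needed for the effect:
compound 1 `COc1ccc2nc(-c3c(C)cccc3C)cc([Se]c3ccccc3)c2c1` — 37300 nM
compound 2 `COc1ccc([Se]c2cc(-c3ccc(O)cc3)nc3ccc(OC)cc23)cc1` — 59200 nM
compound 3 `CCOC(=O)c1cc([Se]c2ccc3cc(OC)ccc3c2)c2cc(Cl)ccc2n1` — 16200 nM

Among these three, compound 1 has the second highest number. Compound 2 is its nearest neighbour, and the gap between the two lies within the usual scatter of this assay, so the two cannot be told apart. Compound 3 is the furthest away, with a lower number, and that gap lies beyond the scatter.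

The next compound, compound 4 `CCOC(=O)c1cc([Se]c2ccccc2)c2cc(OC)ccc2n1`, is reached from compound 1 by a single change: ethoxycarbonyl in place of 2,6-dimethylphenyl on an aromatic carbon. Going by the values given here, no pair of already measured compounds differs in just this way, so the size of the step has to be guessed. Compound 4 shares the ethoxycarbonyl group with compound 3, whose number in this assay is the lowest of the three, so a modest move towards lower numbers is expected, though it may well stay within the scatter.

For compound 4 the expected value in this assay is 20000 nM, in the range 7000 nM to 60000 nM. This estimate means an expected step of a 1.9-fold lower number from compound 1 to compound 4 (0.27 log units; within the scatter), partly because compound 3 gives 16200 nM.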

Compound 4, half-maximal effective concentration: 33000 nM
The estimate for compound 4 lay 1.7-fold (0.22 log units) below the measured number, and the stated range covers the measured number.
By their numbers in this assay, from the lowest: compound 3; then compounds 4, 1 and 2 (each within the scatter of the next).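

In this assay, the aromatic carbon next to the ring nitrogen gets its first direct reading: a 1.1-fold lower number from compound 1 to compound 4 (0.05 log units; within the scatter) appears when ethoxycarbonyl replaces 2,6-dimethylphenyl. Although the change removes a six-membered aromatic ring of carbon only and brings in a group with no ring and 2 hydrogen-bond acceptors, the two compounds cannot be told apart in this read-out, so this position tolerates this particular exchange without a measurable shift. Nothing at hand explains why the two groups give such similar numbers.

Still open, from the compounds shown here alone, is whether a different group at this position, such as a carboxylic acid or an amine, would move the number beyond the scatter. Also open, going by these compounds, is whether the same exchange would give a similarly small step with another group on the selenium.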